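The compounds below may be only part of what the source reports. "The series", "measured", "known", "first", "only" and "open" are said of these compounds alone.

In a functional assay on HepG2 cells (Homo sapiens) for inhibition, read by MTT assay (a lower number here means a stronger inhibitor, a higher number a weaker inhibitor), compound 1 `COc1cc2ncnc(Nc3ccc(NC(=O)c4ccc(F)cc4)cc3)c2cc1OC` gives 15000 nM and compound 2 `COc1cc2ncnc(Nc3ccc(NC(=O)c4ccc(I)cc4)cc3)c2cc1OC` gives 40000 nM, the higher of the two numbers and so the weaker inhibitor of this pair. Within the data shown here, the only measured step is a 2.7-fold higher number from compound 1 to compound 2 (0.43 log units; beyond the scatter), a modest change beyond the scatter, with iodo in place of fluoro on an aromatic carbon.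

The next change leads to compound 3 `COc1cc2ncnc(Nc3ccc(NC(=O)c4c(F)cccc4F)cc3)c2cc1OC`: 2,6-difluorophenyl in place of 4-iodophenyl on a carbonyl carbon. Here 2,6-difluorophenyl stands in place of 4-iodophenyl on a carbonyl carbon. The measured step bears on this only in part: compound 3, like compound 1 at 15000 nM, carries fluoro rather than iodo, but no 2,6-difluorophenyl compound has yet been measured. Reading a 2.7-fold higher number from compound 1 to compound 2 (0.43 log units; beyond the scatter) in reverse, a modest move to a lower number is expected in this assay, no larger than that step, and a result within the scatter cannot be excluded. The expected change is a 2.2-fold lower number from compound 2 to compound 3 (0.35 log units; beyond the scatter). For compound 3 the estimated value is 18000 nM, with an expected range of 7000 nM to 45000 nM.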

Compound 3, half-maximal inhibitory concentration: 17000 nM
Compound 3: the middle estimate sits 1.1-fold (0.02 log units) above what was measured, within the range that was stated.
By their numbers in this assay, from the lowest: compounds 1 and 3 (each within the scatter of the next); then compound 2.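

In this assay, among these compounds, 2,6-difluorophenyl in place of 4-iodophenyl on the carbonyl carbon gives a 2.4-fold lower number from compound 2 to compound 3 (0.37 log units; beyond the scatter), so a second fluorinated ring now sits apart from the iodo compound, and compound 2 no longer has only a single comparison. 2,6-Difluorophenyl in place of 4-fluorophenyl at the same carbonyl carbon gives a 1.1-fold higher number from compound 1 to compound 3 (0.05 log units; within the scatter), so across this pair, the two fluorinated rings cannot be told apart, even though they differ in the number and placing of fluoro groups. No measured property of these groups is available to bear on either step.

With iodo as the only non-fluoro substituent on this ring, the compounds shown leave open whether chloro or bromo at the same ring carbon would read like fluoro or like iodo. They also leave open how this assay responds to a non-halogen group on this ring, such as methoxy, an amine or a carboxylic acid, or to a longer alkyl chain on the carbonyl carbon in place of the aromatic ring.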